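A few compounds are considered here, and "the series" means these few. Any claim that something is new, unique, unknown or untested is made for them only; others in the source may bear on it.

Measured compounds:
compound 1 `NS(=O)(=O)c1ccc(/N=C2\NC(=O)/C(=C3/C(=O)Nc4ccccc43)S2)cc1` gives > 200000 nM in a functional assay on MCF7 cells (Homo sapiens) for antiproliferative activity, read by MTT assay; on this read-out lower numbers stand for stronger inhibition and higher numbers for weaker inhibition — a limit of the assay, not a number.
compound 2 `NS(=O)(=O)c1ccc(/N=C2\NC(=O)/C(=C3/C(=O)N(Cc4ccccc4)c4ccccc43)S2)cc1` gives > 200000 nM in this assay — again a limit of the assay, not a number.

Compound 2 therefore stands only at the limit in this assay, with no number of its own. Within the data shown here, the single measured step, a step that the two limits leave unreadable from compound 1 to compound 2, cannot be read in size, since both values sit at the limit of > 200000 nM in this assay, at which 2 of the 2 values shown sit.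

Compound 3 `CN1C(=O)/C(=C2\S/C(=N/c3ccc(S(N)(=O)=O)cc3)NC2=O)c2ccccc21` differs from compound 2 by hydrogen in place of phenyl on a saturated chain carbon bound to an amide-type nitrogen in a ring. Among the measured compounds shown here, the one measured step touches the same amide-type nitrogen in a ring but offers no readable size, so it gives no basis for a step of any direction in this assay beyond the scatter. Compound 3 is expected to give about 250000 nM, within a range from 60000 nM to 1000000 nM, most likely reported once more as a limit. The step that the limit leaves unreadable from compound 2 to compound 3 is thus estimated as no change beyond the scatter.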

Compound 3, half-maximal inhibitory concentration: 51900 nM
Estimate against measurement, compound 3: 4.8-fold (0.68 log units) above; the whole stated range lies above it.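

In this assay, among these compounds, this amide-type nitrogen in a ring turns out to be a position that can move the read-out, and compound 3, with methyl, is the only one of the three compounds to give a number rather than a limit. Replacing benzyl by methyl gives an at least 3.8-fold lower number from compound 2 to compound 3 (0.58 log units; beyond the scatter), and placing methyl on the nitrogen in place of hydrogen gives an at least 3.8-fold lower number from compound 1 to compound 3 (0.58 log units; beyond the scatter), so the methyl compound differs from both the smaller and the larger group shown. The size of each step stays open-ended, because each starts from a value that is a limit of the assay, not a number: the limit of > 200000 nM in this assay, at which 2 of the 3 values shown sit.

Going by these compounds, whether an ethyl group, a longer chain or a chain ending in an amine would shift the number further remains open. With only compound 3 off the limit, no trend with chain size can be drawn.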